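Dimethylamino in place of bromo: expected inhibition

A few compounds are considered here, and "the series" means these few. Any claim that something is new, unique, unknown or untested is made for them only; others in the source may bear on it.

compound 1 `O=c1ccn(COCCO)c(=O)[nH]1` — > 400 ug/mL
compound 2 `Nc1nc2c(nc(Br)n2COCCO)c(=O)[nH]1` — 340 ug/mL

Within the data shown here, in a functional assay (Oryctolagus cuniculus) for inhibition (a higher number here means a weaker inhibitor, a lower number a stronger inhibitor), compound 2 gives 340 ug/mL, the only number in the set. For compound 1 the result is a limit of the assay, > 400 ug/mL, which is the limit of > 400 ug/mL in this assay, at which 1 of the 2 values shown sits. Compound 3 `CN(C)c1nc2c(=O)[nH]c(N)nc2n1COCCO` differs from compound 2 by dimethylamino in place of bromo on an aromatic carbon. Among the measured compounds shown here, no measured step covers this change, so no size can be read from the data. Compound 3 is expected to stay close to compound 2, the step of a 1.2-fold higher number from compound 2 to compound 3 (0.07 log units; within the scatter) being none beyond the scatter or slightly toward weaker. The estimate for compound 3 is 400 ug/mL, range 150 ug/mL to 1000 ug/mL.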

Compound 3, concentration for 50% inhibition: > 400 ug/mL
Compound 3: no number, only a limit (the forecaster's own chance of this, stated with the estimate: 50%); the middle value sits exactly at the limit.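

In this assay, dimethylamino in place of bromo on an aromatic carbon gives an at least 1.1-fold higher number from compound 2 to compound 3 (0.07 log units; that floor lies within the scatter). Compound 3 gives a limit and not a number, and the step has only a floor; its true size cannot be read. Compound 2 remains the only compound with a number: the limit of > 400 ug/mL in this assay, at which 2 of the 3 values shown sit.

Going by these compounds, whether any group at this position gives a lower number than compound 2 stays open. Chloro, methyl or a primary amine on the same aromatic carbon would show whether the inhibition seen with compound 2 depends on bromo.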